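Cytotoxicity of a triazole-linked naphthoquinone series on liver cells

A few compounds are considered here, and "the series" means these few. Any claim that something is new, unique, unknown or untested is made for them only; others in the source may bear on it.

Compound 1 `CC(C)=CCC1=C(OCc2cn(-c3ccnc4cc(Cl)ccc34)nn2)C(=O)c2ccccc2C1=O`: 1940000 nM
Compound 2 `CC(C)=CCC1=C(OCc2cn(Cc3ccccc3)nn2)C(=O)c2ccccc2C1=O`: 414000 nM

In an ADME assay on HepG2 cells (Homo sapiens) for cytotoxicity, read by MTT assay, with a stated time of 24 h (on this read-out lower numbers stand for higher toxicity in this test and higher numbers for lower toxicity in this test), compound 2 gives the lowest of the two numbers; compound 1 stands a 4.7-fold lower number from compound 1 to compound 2 (0.67 log units; beyond the scatter) away. Compound 3 `CC(C)=CCC1=C(OCc2cn(Cc3ccccn3)nn2)C(=O)c2ccccc2C1=O` carries pyridin-2-yl in place of phenyl on a saturated chain carbon bound to an aromatic nitrogen. No measured step exchanges a phenyl for a pyridin-2-yl here, so nothing shown bears directly on this change; the only measured step concerns the group on the aromatic nitrogen. For compound 3 the expected change is a 1.2-fold higher number from compound 2 to compound 3 (0.08 log units; within the scatter), not beyond the scatter. Compound 3 is therefore estimated at 500000 nM, within 200000 nM to 1300000 nM.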

Compound 3, half-maximal cytotoxic concentration: 658000 nM
Beside the measured number, compound 3's estimate is 1.3-fold (0.12 log units) below it; measured number inside the range.
By their numbers in this assay, from the lowest: compounds 2 and 3 (each within the scatter of the next); then compound 1.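

In this assay, the step of a 1.6-fold higher number from compound 2 to compound 3 (0.20 log units; within the scatter) lies within the scatter, so on a saturated chain carbon bound to an aromatic nitrogen, pyridin-2-yl and phenyl cannot be told apart. The step of a 2.9-fold lower number from compound 1 to compound 3 (0.47 log units; beyond the scatter) lies beyond the scatter, so (pyridin-2-yl)methyl, like benzyl, stands apart from 7-chloroquinolin-4-yl on the aromatic nitrogen. No measurement offers an explanation for these numbers. The compounds shown leave open whether a pyridin-3-yl group, an amine on the ring or a longer chain in place of the single chain carbon would move the number beyond the scatter from compound 2.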